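Phenyl on the Amide-Type Nitrogen of Compound 3

The compounds below may be only part of what the source reports. "The series", "measured", "known", "first", "only" and "open" are said of these compounds alone.

Measured in a functional assay on MDA-MB-453 cells (Homo sapiens) for antiproliferative activity, read by MTT assay, with a stated time of 72 h; on this read-out higher numbers stand for weaker inhibition and lower numbers for stronger inhibition:
- compound 1 `O=C1NN=C(c2ccccc2)/C1=C/Nc1cc(-c2ccco2)[nH]n1`: 20900 nM
- compound 2 `O=C1NN=C(c2ccccc2)/C1=C/Nc1cc[nH]n1`: 74900 nM
- compound 3 `O=C1NN=C(c2ccccc2)/C1=C/Nc1cc(-c2ccccc2)[nH]n1`: 11500 nM

Compound 3 cannot be separated from compound 1, since a 1.8-fold lower number from compound 1 to compound 3 (0.26 log units; within the scatter) lies within the scatter. It does stand apart from compound 2, as a 6.5-fold lower number from compound 2 to compound 3 (0.81 log units; beyond the scatter) lies beyond it.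

Compound 4 `O=C1/C(=C\Nc2cc(-c3ccccc3)[nH]n2)C(c2ccccc2)=NN1c1ccccc1` differs by phenyl in place of hydrogen on an amide-type nitrogen in a ring. Within the data shown here, no measured step touches that nitrogen. Among the measured compounds shown here, the only guide is phenyl placed on an aromatic carbon, a 6.5-fold lower number from compound 2 to compound 3 (0.81 log units; beyond the scatter), alongside a 3.6-fold higher number from compound 1 to compound 2 (0.55 log units; beyond the scatter). A smaller step towards a lower number is therefore expected, though only loosely. The estimated step is a 1.8-fold lower number from compound 3 to compound 4 (0.25 log units; within the scatter). Compound 4 is expected at 6500 nM, within an estimated range of 2000 nM to 20000 nM.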

Compound 4, half-maximal inhibitory concentration: 8750 nM
Compound 4: middle estimate off by 1.3-fold (0.13 log units), on the low side, within the range that was stated.
By their numbers in this assay, from the lowest: compounds 4, 3 and 1 (each within the scatter of the next, the first and the last beyond it); then compound 2.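

In this assay phenyl in place of hydrogen on the amide-type nitrogen in a ring gives a 1.3-fold lower number from compound 3 to compound 4 (0.12 log units; within the scatter) and leaves compound 4 inseparable from compound 3. This position therefore accepts a phenyl group with no difference that the assay can resolve, whereas phenyl in place of hydrogen on an aromatic carbon gave a 6.5-fold lower number from compound 2 to compound 3 (0.81 log units; beyond the scatter) and lay beyond the scatter.

The compounds shown leave open whether a methyl group, an amine or a carboxylic acid on this nitrogen would read differently, and no measurement given here accounts for the result.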